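The source may report more compounds than this note shows. Statements on the series, on what has been measured and on what is new or still open speak of the compounds shown alone.

Working notes on the series in a functional assay on HL-60 cells (Homo sapiens) for cytotoxicity, read by MTT assay, with a stated time of 48 h; on this read-out higher numbers stand for weaker inhibition and lower numbers for stronger inhibition.

Going by the values given here, compound 1 `COc1ccc(Nc2nc(-c3cccc(F)c3)nc3ccc(F)cc23)cc1` is the only member of the set with a numeric reading: in this assay compound 1 gives 38600 nM. Compound 2 `Fc1cccc(-c2nc(Nc3ccccc3F)c3cc(F)ccc3n2)c1` returns only a limit of the assay, > 50000 nM, and not a number. Compound 3 `Fc1cccc(-c2nc(Nc3cccc(Cl)c3)c3cc(F)ccc3n2)c1` likewise returns only the limit > 50000 nM. Both readings sit at the limit of > 50000 nM in this assay, at which 2 of the 3 values shown sit, so compound 1 stands at the bottom of the three on the numbers shown, with the other two unresolved above it.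

The measured steps from compound 1 are an at least 1.2-fold higher number from compound 1 to compound 2 (0.11 log units; that floor lies within the scatter) and an at least 1.2-fold higher number from compound 1 to compound 3 (0.11 log units; that floor lies within the scatter); the floor of each lies within the scatter, so neither fixes a size. Between compound 2 and compound 3 the step is a step that the two limits leave unreadable from compound 2 to compound 3.

Compound 4 `Oc1cccc(Nc2nc(-c3cccc(F)c3)nc3ccc(F)cc23)c1` differs from compound 1 by 3-hydroxyphenyl in place of 4-methoxyphenyl on a nitrogen on an aromatic ring. Among the compounds with values here, no measured pair carries the same change, and the two pairs that do alter the same group only set floors. The expectation for compound 4 is therefore a number near that of compound 1 or somewhat higher, with a fair chance that it lands at the limit. Compound 4 is estimated at 45000 nM, between 15000 nM and 120000 nM, meaning an expected step of a 1.2-fold higher number from compound 1 to compound 4 (0.07 log units; within the scatter).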

Compound 4, half-maximal inhibitory concentration: > 50000 nM
Compound 4: only a limit was reported; the forecaster's own chance of this, stated with the estimate: 40%; at least 1.1-fold (0.04 log units) between middle value and limit.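

The new reading extends the pattern on this nitrogen: the 3-hydroxyphenyl group, with the hydrogen-bond donor that the 4-methoxyphenyl group lacks, still gives no number, only a limit of the assay. In this assay the step is an at least 1.2-fold higher number from compound 1 to compound 4 (0.11 log units; that floor lies within the scatter); it rests on that limit, so this floor sets no size for the change. Compound 1 thus remains the only member of the set with a numeric reading, and the steps among compound 2, compound 3 and compound 4 cannot be read, because each has a limit at both ends: the limit of > 50000 nM in this assay, at which 3 of the 4 values shown sit.

The change from compound 1 to compound 4 moves the oxygen on the ring and removes its methyl in a single step, and the two effects could be separated only by the 3-methoxyphenyl and 4-hydroxyphenyl groups on the same nitrogen. From the compounds shown here alone, it also remains open whether a basic amine on the aniline ring, such as a 4-(dimethylamino)phenyl group, or a carboxylic acid there would bring a reading to a number clearly apart from that of compound 1.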